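Allyloxycarbonyl to Phenylcarbamoyl: Estimating Compound 4

The source may report more compounds than this note shows. Statements on the series, on what has been measured and on what is new or still open speak of the compounds shown alone.

Three compounds sharing one core were tested in a functional assay on HEK293 cells for agonist activity at nuclear receptor subfamily 1 group D member 1 (Homo sapiens), read by a luciferase reporter, with a stated time of 24 h; on this read-out higher numbers stand for an effect only at larger amounts of compound and lower numbers for an effect already at smaller amounts:

Compound 1, `CN1CCC(CN(Cc2ccc(Cl)cc2)Cc2ccc([N+](=O)[O-])s2)C1`: "not determined" (no result reported).
Compound 2, `CC(=O)N1CCC(CN(Cc2ccc(Cl)cc2)Cc2ccc([N+](=O)[O-])s2)C1`: 1600 nM.
Compound 3, `C=CCOC(=O)N1CCC(CN(Cc2ccc(Cl)cc2)Cc2ccc([N+](=O)[O-])s2)C1`: 670 nM.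

Compound 3 stands lowest of the two numbers available. Its nearest neighbour is compound 2, and the step of a 2.4-fold lower number from compound 2 to compound 3 (0.38 log units; beyond the scatter) lies beyond the scatter. Compound 1 carries no number and gives no guidance.

Compound 4, `O=C(Nc1ccccc1)N1CCC(CN(Cc2ccc(Cl)cc2)Cc2ccc([N+](=O)[O-])s2)C1`, differs from compound 3 in a single place: anilino in place of allyloxy on a carbonyl carbon. Among the measured compounds shown here, only one measured step touches this carbonyl carbon, the modest change a 2.4-fold lower number from compound 2 to compound 3 (0.38 log units; beyond the scatter). For the measured compounds named here, that step replaced a methyl with an allyloxy; the present step replaces the allyloxy with an anilino, and no measured pair shows a change of this kind. Going by the values given here, the one step on record at this position lowered the number, so the expectation rests on that alone and is held loosely: a small step in the direction of a lower number, close to the scatter. Compound 4 is therefore estimated at 500 nM, with a range from 150 nM to 2000 nM. The step this estimate implies, a 1.3-fold lower number from compound 3 to compound 4 (0.13 log units; within the scatter), is expected rather than known.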

Compound 4, half-maximal effective concentration: 620 nM
For compound 4 the middle estimate is 1.2-fold (0.09 log units) below the measured one; the range from low to high includes it.
By their numbers in this assay, from the lowest: compounds 4 and 3 (each within the scatter of the next); then compound 2.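

In this assay the exchange of allyloxy for anilino on this carbonyl carbon gives a 1.1-fold lower number from compound 3 to compound 4 (0.03 log units; within the scatter) and so the two groups cannot be told apart on this read-out. The position therefore accepts an aromatic ring of carbon only and a hydrogen-bond donor in place of a chain with a double bond outside aromatic rings, with no change beyond the scatter. Anilino in place of methyl gives a 2.6-fold lower number from compound 2 to compound 4 (0.41 log units; beyond the scatter) and this modest step joins a 2.4-fold lower number from compound 2 to compound 3 (0.38 log units; beyond the scatter) as a second step in the same direction, so among the three compounds with a number, both larger groups differ from the methyl of compound 2 while not differing from each other.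

Going by these compounds, how a dimethylamino group, a benzyloxy group or a longer chain would read on this carbonyl carbon stays open, and the steps to compound 1 cannot be read, which leaves the need for the carbonyl itself open as well. No supporting data bear on why allyloxy and anilino read alike here.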